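Trading heptyloxy for trifluoromethyl on the shared core

The compounds below may be only part of what the source reports. "The series", "measured", "known", "first", "only" and "open" are said of these compounds alone.

In a functional assay on HL-60 cells (Homo sapiens) for cytotoxicity, read by WST assay, with a stated time of 48 h (on this read-out higher numbers stand for an effect only at larger amounts of compound and lower numbers for an effect already at smaller amounts), compound 1 (`CCCCOc1ccc(C[C@H]2C(=O)OC[C@@H]2Cc2ccccc2)cc1`) gives 23000 nM as its value. Compound 2 (`CCCCCCCOc1ccc(C[C@H]2C(=O)OC[C@@H]2Cc2ccccc2)cc1`) gives > 100000 nM as a limit of the assay and not a number, so it stands at the limit of > 100000 nM in this assay, at which 1 of the 2 values shown sits, and has no exact place. Compound 3 (`O=C1OC[C@H](Cc2ccccc2)[C@H]1Cc1ccc(C(F)(F)F)cc1`) differs from compound 2 by trifluoromethyl in place of heptyloxy on an aromatic carbon with trifluoromethyl in place of heptyloxy on an aromatic carbon. For the measured compounds named here, only one measured step bears on this change: an at least 4.3-fold higher number from compound 1 to compound 2 (0.63 log units; beyond the scatter) lies beyond the scatter, with the higher number on the longer chain, though it does not involve trifluoromethyl. With the heptyloxy chain gone, a step of at least modest size toward a lower number is expected in this assay as a rough reading. The estimated move is an at least 2.5-fold lower number from compound 2 to compound 3 (0.39 log units; beyond the scatter) in this reckoning. For compound 3 the estimated value is 40000 nM with an expected range of 12000 nM to 100000 nM as its span.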

Compound 3, half-maximal effective concentration: 22000 nM
Compound 3: the middle estimate sits 1.8-fold (0.26 log units) above what was measured; measured number inside the range.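

Compound 2 carries a limit of the assay and not a number: the limit of > 100000 nM in this assay, at which 1 of the 3 values shown sits. On the aromatic carbon para to a large group, trifluoromethyl in place of heptyloxy gives an at least 4.5-fold lower number from compound 2 to compound 3 (0.65 log units; beyond the scatter), which shows that a group without an oxygen or a chain can give a measurable value in this assay. Trifluoromethyl in place of butoxy gives a 1.0-fold lower number from compound 1 to compound 3 (0.02 log units; within the scatter), so compound 1 and compound 3 cannot be told apart here, something the earlier pair, which differed only in chain length, could not show.

The compounds shown leave open whether an amine or a carboxylic acid on this aromatic carbon would read like compound 3. They also leave open where along the chain, for instance with a pentyloxy or hexyloxy group, the value would leave the range of compound 1.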